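A few compounds are considered here, and "the series" means these few. Any claim that something is new, unique, unknown or untested is made for them only; others in the source may bear on it.

Measured in a functional assay for inhibition, with Homo sapiens as the target; a higher number here means a weaker inhibitor, a lower number a stronger inhibitor:
- Compound 1 `CC(C)Oc1c(C(=O)Nc2nn[nH]n2)sc2ccc(O)cc12`: 47800 nM
- Compound 2 `CC(C)Oc1c(C(=O)Nc2nn[nH]n2)sc2ccc(Cl)cc12`: > 100000 nM (a limit)
- Compound 3 `CC(C)Oc1c(C(=O)Nc2nn[nH]n2)sc2ccc(Oc3ccccc3)cc12`: > 100000 nM (a limit)

Compound 3 has no numerical value, only a limit. It stands at the limit of > 100000 nM in this assay, at which 2 of the 3 values shown sit.

Compound 4 `CC(C)Oc1c(C(=O)Nc2nn[nH]n2)sc2ccc(OCc3ccccc3)cc12` carries benzyl in place of phenyl on an oxygen on an aromatic ring. Among the compounds with values here, no measured step makes this exchange. The nearest evidence is an at least 2.0-fold higher number from compound 1 to compound 3 (0.32 log units; beyond the scatter), alongside an at least 2.0-fold higher number from compound 1 to compound 2 (0.32 log units; beyond the scatter). Both leave the hydroxy compound for the limit, while a step that the two limits leave unreadable from compound 2 to compound 3. Given the step to compound 3 of an at least 2.0-fold higher number from compound 1 to compound 3 (0.32 log units; beyond the scatter), no step beyond the scatter is expected, and the expected change is a number no higher from compound 3 to compound 4 (the limit leaves the size open). For compound 4 the estimated value is 100000 nM, with an expected range of 40000 nM to 200000 nM.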

Compound 4, half-maximal inhibitory concentration: > 100000 nM
Compound 4: no number, only a limit (the forecaster's own chance of this, stated with the estimate: 65%); the middle value lies on the limit itself.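

In this assay, benzyl on the oxygen gives an at least 2.0-fold higher number from compound 1 to compound 4 (0.32 log units; beyond the scatter), so a third replacement of the hydroxy compound ends at the limit, now with one more carbon in the group than phenyl. The steps among compound 2, compound 3 and compound 4 cannot be read, so the exchange of phenyl for benzyl has no measurable size. Only compound 1 has a number, and the others share one limit: the limit of > 100000 nM in this assay, at which 3 of the 4 values shown sit.

Still open, on these data alone, is whether a methoxy, an amine or a carboxylic acid on this aromatic carbon would give a number under the limit. Also open, as far as these compounds go, is how far the value of compound 1 depends on the hydroxy group.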